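This account rests on a few compounds, and the source may have more. Where it says the series, first, only, none or still open, it means among the compounds named here.

In a functional assay on A549 cells (Homo sapiens) for antiproliferative activity, read by MTT assay, with a stated time of 48 h (a higher number here means a weaker inhibitor, a lower number a stronger inhibitor), three compounds have been measured:

compound 1 `Cc1ccc2nc(NC(c3cn(-c4ccccc4)nc3-c3cccc([N+](=O)[O-])c3)c3c(O)ccc4ccccc34)sc2c1`: 57400 nM
compound 2 `Cc1ccc2nc(NC(c3cn(-c4ccccc4)nc3-c3cccc(Cl)c3)c3c(O)ccc4ccccc34)sc2c1`: 45400 nM
compound 3 `COc1ccc(-c2nn(-c3ccccc3)cc2C(Nc2nc3ccccc3s2)c2c(O)ccc3ccccc23)cc1`: 26200 nM

Compound 2, at 45400 nM, lies within the scatter of both compound 1 and compound 3, so its place among these three numbers carries little weight.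

The compound still to be measured is compound 4 `Oc1ccc2ccccc2c1C(Nc1nc2ccc(Cl)cc2s1)c1cn(-c2ccccc2)nc1-c1cccc(Cl)c1`. It differs from compound 2 in one place: chloro in place of methyl on an aromatic carbon. This is chloro in place of methyl on an aromatic carbon, which turns 6-methyl-1,3-benzothiazol-2-yl into 6-chloro-1,3-benzothiazol-2-yl.

For the measured compounds named here, only one measured step changes a single place, a 1.3-fold lower number from compound 1 to compound 2 (0.10 log units; within the scatter), and it lies within the scatter. That step is chloro in place of nitro on an aromatic carbon at another place in the molecule, so it bears on this change only indirectly. Going by the values given here, compound 3 differs from compound 2 in more than one place and gives no clean step. Among the compounds with values here, no measured pair covers chloro in place of methyl, so no step beyond the scatter is expected in this assay.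

The expected step is a 1.1-fold lower number from compound 2 to compound 4 (0.05 log units; within the scatter), which is estimated to stay within the scatter. Compound 4 is estimated at 40000 nM, with an expected range of 18000 nM to 85000 nM.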

Compound 4, half-maximal inhibitory concentration: 33300 nM
Estimate against measurement, compound 4: 1.2-fold (0.08 log units) above; the measured number falls inside the stated range.
By their numbers in this assay, from the lowest: compounds 3, 4, 2 and 1 (each within the scatter of the next, the first and the last beyond it).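

In this assay the exchange of 6-methyl-1,3-benzothiazol-2-yl for 6-chloro-1,3-benzothiazol-2-yl gives a 1.4-fold lower number from compound 2 to compound 4 (0.13 log units; within the scatter) and so stays within the scatter. This is the first single-place change shown at this position, since the earlier step between measured compounds changed another place, and it shows that methyl and chloro on this aromatic carbon cannot be told apart in this read-out. Nothing available bears on why the two groups read alike.

The compounds shown leave open whether this position would respond at all to a group of another kind, such as an amine, a carboxylic acid or a longer chain in place of chloro or methyl. Compound 3 carries no group at this position but also differs from compound 2 and compound 4 in another place, so the effect of leaving this aromatic carbon bare cannot be read from it alone.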